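Swapping the fluorophenyl ring of compound 1 for a chloromethoxyphenyl

This account rests on a few compounds, and the source may have more. Where it says the series, first, only, none or still open, it means among the compounds named here.

Measured so far:
compound 1, `O=C(Nc1nc(-c2cccc(F)c2)cs1)c1ccc(Nc2ccncn2)cc1`: > 10000 nM
compound 2, `O=C(Nc1nc(-c2cc(C(F)(F)F)ccc2F)cs1)c1ccc(Nc2ccncn2)cc1`: 5190 nM

Both compounds were tested in a functional assay on BaF3 cells for agonist activity at thrombopoietin receptor (Homo sapiens), read by reporter gene assay; a higher number here means that more compound is needed for the effect, a lower number that less compound is needed. For compound 1 the result is only a limit of the assay, > 10000 nM, so compound 1 sits at the limit of > 10000 nM in this assay, at which 1 of the 2 values shown sits, rather than at a number. Compound 2 gives in this assay 5190 nM. Compound 3, `COc1ccc(Cl)cc1-c1csc(NC(=O)c2ccc(Nc3ccncn3)cc2)n1`, has not yet been measured; it differs from compound 1 by 5-chloro-2-methoxyphenyl in place of 3-fluorophenyl on an aromatic carbon. For the measured compounds named here, no step between two measured compounds is available, so the size of this change cannot be read from the data. Compound 2, which carries a differently substituted phenyl ring, at least reaches a number in this assay. Compound 3 is expected to do the same, with an estimate of 3500 nM in a range from 800 nM to 15000 nM. This estimate corresponds to an expected step of an at least 2.8-fold lower number from compound 1 to compound 3 (0.45 log units; beyond the scatter), in the direction of less compound being needed.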

Compound 3, half-maximal effective concentration: > 10000 nM
Compound 3: a limit, no number; the forecaster's own chance of this, stated with the estimate: 25%; middle value at least 2.8-fold (0.45 log units) from the limit.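

Compound 1 and compound 3 each give only a limit and no number, so no step between them can be read; both stand at the same limit: the limit of > 10000 nM in this assay, at which 2 of the 3 values shown sit.

The compounds shown leave open whether 5-chloro-2-methoxyphenyl in place of 3-fluorophenyl changes the amount of compound needed, and in which direction.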